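A few compounds are considered here, and "the series" means these few. Any claim that something is new, unique, unknown or untested is made for them only; others in the source may bear on it.

Measured so far in a functional assay, read by Griess assay, with a stated time of 150 min, tested at 50 ug/mL; on this read-out higher numbers stand for a stronger effect at the one concentration tested and lower numbers for a weaker effect:
- compound 1, `O=S(=O)(CC1=NCCS1)c1c(-c2ccccc2)noc1-c1ccccc1`: "not active" (no number reported)
- compound 2, `COc1ccc(C2=NOC(c3ccc(C)cc3)C2S(=O)(=O)CC2=NCCO2)cc1`: 61.9%

Compound 1 is reported in this assay only as "not active" (no number reported), without a number. Within the data shown here, compound 2 is therefore the only compound of the pair with a number in this assay, 61.9%, and it stands alone as the reference point; its two structures differ in several places at once, so nothing of a single step can be read from compound 1 against compound 2.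

Compound 3, `COc1ccc(C2=NOC(c3ccc(C)cc3)C2S(=O)(=O)CC2=NCCS2)cc1`, is not yet measured. It differs from compound 2 in one place: a group of 5 heavy atoms (3 carbon, 1 nitrogen, 1 sulfur; one five-membered non-aromatic ring with 2 hetero atoms) in place of a group of 5 heavy atoms (3 carbon, 1 nitrogen, 1 oxygen; one five-membered non-aromatic ring with 2 hetero atoms), on a saturated chain carbon bound to a sulfonyl sulfur.

Among the measured compounds shown here, no step between measured compounds is available for this change. The read-out of compound 1, which carries the entering group but also differs elsewhere, gives no usable direction. With nothing further to go on, the step from compound 2 to compound 3 is expected to be small, at most a slight fall, and likely to remain within the usual scatter, as a number 6.9 percentage points lower from compound 2 to compound 3 (within the scatter). For compound 3 the expected activity is estimated at 55%, within a range from 30% to 75%.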

Compound 3, a percentage reported as activity, at one concentration (the size of the read-out at that concentration, not a potency): 48.6%
For compound 3 the middle estimate is 6.4 percentage points above the measured one, within the range that was stated.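

In this assay, among these compounds, this is the first single-place change readable: on a saturated chain carbon bound to a sulfonyl sulfur, the five-membered non-aromatic ring with 2 hetero atoms carrying sulfur replaces the one carrying oxygen, giving a number 13.3 percentage points lower from compound 2 to compound 3 (beyond the scatter). The position therefore responds to an exchange of one ring atom, even though the heavy-atom count, hydrogen-bond donor and acceptor counts and net charge of the group stay the same, and the effect is not lost on this core, since compound 3 still gives 48.6%. No measured information bears on the reason for this step.

Open, from the compounds shown here alone, is whether a group of another kind on the same carbon, such as an amine, a carboxylic acid, a nitrile or a six-membered morpholine ring, would raise or lower the read-out relative to these two rings. Also open, going by these compounds, is whether the same exchange of oxygen for sulfur gives a step of the same direction on other cores, since this one step, read at a single concentration, rests on one pair and gives no potency.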